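Working notes: urea to amide step toward compound 4

A few compounds are considered here, and "the series" means these few. Any claim that something is new, unique, unknown or untested is made for them only; others in the source may bear on it.

Measured so far in a functional assay on KM12 cells (Homo sapiens) for inhibition, read by sulforhodamine B assay, with a stated time of 48 h, tested at 0.1 uM; a higher number here means a weaker effect of the compound at the concentration tested, a lower number a stronger effect:
compound 1 `COc1cc(Cl)cc(-c2nn(-c3cccc(NC(=O)Nc4ccc(Cl)c(C(F)(F)F)c4)c3)cc2-c2ccncc2)c1` gives 98%
compound 2 `COc1cc(Cl)cc(-c2nn(-c3cccc(NC(=O)Nc4ccc(Cl)c(Cl)c4)c3)cc2-c2ccncc2)c1` gives 92%
compound 3 `COc1cc(Cl)cc(-c2nn(-c3cccc(NC(=O)Nc4cccc(C(F)(F)F)c4)c3)cc2-c2ccncc2)c1` gives 95%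

Compound 3 stands second highest of the three numbers in this assay; compound 1 is its nearest neighbour and compound 2 the furthest, and all three numbers sit close together. The three measured steps are each within the scatter: a number 6 percentage points lower from compound 1 to compound 2 (within the scatter), a number 3 percentage points lower from compound 1 to compound 3 (within the scatter), a number 3 percentage points higher from compound 2 to compound 3 (within the scatter). Compound 4 `COc1cc(Cl)cc(-c2nn(-c3cccc(NC(=O)c4cccc(C(F)(F)F)c4)c3)cc2-c2ccncc2)c1` is not yet measured. The change from compound 3 is 3-(trifluoromethyl)phenyl in place of (3-(trifluoromethyl)phenyl)amino on a carbonyl carbon. Among the compounds with values here, no measured step bears on this change; the measured steps vary only the groups on the terminal aromatic ring. Since all three numbers lie within the scatter of one another, no step beyond the scatter is expected, the expected step being no change at the digits printed from compound 3 to compound 4 (within the scatter). Compound 4 is expected to give 95% in this assay, with a range from 82% to 105%.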

Compound 4, a percentage reported as activity, at one concentration (the size of the read-out at that concentration, not a potency): 111%
Compound 4: middle estimate off by 16 percentage points, on the low side; measured number above the stated range.
By their numbers in this assay, from the lowest: compounds 2, 3 and 1 (each within the scatter of the next); then compound 4.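

In this assay replacing the arylamino group on the carbonyl carbon with the aryl group directly gives a number 16 percentage points higher from compound 3 to compound 4 (beyond the scatter) and, with the terminal ring also differing, a number 19 percentage points higher from compound 2 to compound 4 (beyond the scatter) and a number 13 percentage points higher from compound 1 to compound 4 (beyond the scatter) as well. This position therefore moves the read-out towards a weaker effect, whereas the terminal ring changes among compound 1, compound 2 and compound 3 all stayed within the scatter. Nothing available accounts for this step.

Open, going by these compounds, is whether a methylene or an ether oxygen in place of the amino nitrogen would track compound 3 or compound 4. Also open, on these data alone, is whether the 3,4-dichlorophenyl group on this carbonyl carbon would behave like the 3-(trifluoromethyl)phenyl group.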